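Hydroxy to methyl on two coumarin-triazole cores

A few compounds are considered here, and "the series" means these few. Any claim that something is new, unique, unknown or untested is made for them only; others in the source may bear on it.

Compound 1 `O=c1cc(Cn2cc(-n3ccc4cc(I)ccc43)nn2)c2ccc(O)cc2o1`: 34300 nM
Compound 2 `Cc1ccc2c(Cn3cc(-n4ccc5cc(I)ccc54)nn3)cc(=O)oc2c1`: 70000 nM
Compound 3 `Cn1c(-c2cn(Cc3cc(=O)oc4cc(O)ccc34)nn2)nc2ccccc21`: > 100000 nM

In a functional assay on SW-620 cells (Homo sapiens) for inhibition, read by MTT assay, with a stated time of 72 h (on this read-out higher numbers stand for weaker inhibition and lower numbers for stronger inhibition), compound 1 gives 34300 nM and compound 2 gives 70000 nM. The change between them is methyl in place of hydroxy on an aromatic carbon, and it produced a 2.0-fold higher number from compound 1 to compound 2 (0.31 log units; beyond the scatter). Compound 3 carries a different core; the difference between the two cores is not broken down here. In this assay compound 3 reaches only a limit of the assay, > 100000 nM, so that compound sits at the limit of > 100000 nM in this assay, at which 1 of the 3 values shown sits. Compound 4 `Cc1ccc2c(Cn3cc(-c4nc5ccccc5n4C)nn3)cc(=O)oc2c1` is not yet measured; it differs from compound 3 by methyl in place of hydroxy on an aromatic carbon, the same change as that from compound 1 to compound 2. Since compound 3 already stands at the limit and the earlier step weakened inhibition, compound 4 is expected to show a step that the limit leaves unreadable from compound 3 to compound 4, most likely again reported only as a limit. The estimate for compound 4 is 200000 nM.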

Compound 4, half-maximal inhibitory concentration: > 100000 nM
Compound 4 ended at the assay's limit; the forecaster's own chance of this, stated with the estimate: 85%; the middle value does not contradict the limit.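

For the compounds shown here, compound 3 and compound 4 both sit at a limit of the assay, so no step between them can be read: the limit of > 100000 nM in this assay, at which 2 of the 4 values shown sit. The compounds shown leave open whether methyl in place of hydroxy changes inhibition on the core of compound 3.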